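Swapping Cyclopropyl for Piperidinyl on the Shared Core

A few compounds are considered here, and "the series" means these few. Any claim that something is new, unique, unknown or untested is made for them only; others in the source may bear on it.

Of the compounds shown here, three sharing one core have been measured in a functional assay on K562 cells (Homo sapiens) for inhibition, read by MTT assay, with a stated time of 96 h; a lower number here means a stronger inhibitor, a higher number a weaker inhibitor. Compound 1 `Cc1cc(C)c(-c2csc(NC(=O)/C=C/c3ccc([N+](=O)[O-])cc3)n2)c(C)c1` gives 32200 nM, compound 2 `Cc1cc(C)c(-c2csc(NC(=O)/C=C/c3ccc(C(F)(F)F)cc3)n2)c(C)c1` gives 480 nM, and compound 3 `Cc1cc(C)c(-c2csc(NC(=O)/C=C/c3ccc(C4CC4)cc3)n2)c(C)c1` gives 380 nM. Compound 3 has the lowest number of the three: the steps of an 85-fold lower number from compound 1 to compound 3 (1.93 log units; beyond the scatter) and a 67-fold lower number from compound 1 to compound 2 (1.83 log units; beyond the scatter) are large, while a 1.3-fold lower number from compound 2 to compound 3 (0.10 log units; within the scatter) lies within the scatter. Compound 4 `Cc1cc(C)c(-c2csc(NC(=O)/C=C/c3ccc(N4CCCCC4)cc3)n2)c(C)c1` differs from compound 3 by piperidin-1-yl in place of cyclopropyl on an aromatic carbon. Going by the values given here, no measured step exchanges cyclopropyl for a nitrogen-containing ring; the step of a 1.3-fold lower number from compound 2 to compound 3 (0.10 log units; within the scatter) shows two unlike groups giving similar numbers, whereas nitro stands far apart. The expected step of a 1.8-fold higher number from compound 3 to compound 4 (0.27 log units; within the scatter) is therefore small, with wide uncertainty. Compound 4 is estimated at 700 nM, within 200 nM to 3000 nM.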

Compound 4, half-maximal inhibitory concentration: 4060 nM
Compound 4: the middle estimate sits 5.8-fold (0.76 log units) below what was measured; measured number outside the range, above it.
By their numbers in this assay, from the lowest: compounds 3 and 2 (each within the scatter of the next); then compound 4; then compound 1.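

In this assay, this position on the six-membered aromatic ring does not simply split nitro from everything else: an 11-fold higher number from compound 3 to compound 4 (1.03 log units; beyond the scatter) and an 8.5-fold higher number from compound 2 to compound 4 (0.93 log units; beyond the scatter) set piperidin-1-yl well apart from cyclopropyl and trifluoromethyl, while a 7.9-fold lower number from compound 1 to compound 4 (0.90 log units; beyond the scatter) keeps it apart from nitro too. The four groups therefore fall on three distinct levels, with piperidin-1-yl in the middle. Nothing measured here explains this order. Still open, going by these compounds, is whether the higher number goes with the ring nitrogen or with the larger ring. An all-carbon cyclohexyl group and an open-chain dimethylamino group would help separate the two.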